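Thiazole-carboxamide indoles: fluoro for methoxy on the indole

The source may report more compounds than this note shows. Statements on the series, on what has been measured and on what is new or still open speak of the compounds shown alone.

Measured compounds:
- compound 1, `COc1ccc(NC(=O)c2csc(-c3cn(Cc4ccc(Cl)cc4)c4ccccc34)n2)cc1`, > 100000 nM
- compound 2, `COc1ccc2[nH]cc(-c3nc(C(=O)Nc4cc(OC)c(OC)c(OC)c4)cs3)c2c1`, > 100000 nM
- compound 3, `Cc1ccc(NC(=O)c2csc(-c3c[nH]c4ccccc34)n2)cc1`, > 100000 nM

All three measured compounds share a thiazole-carboxamide linked to an indole. In a functional assay on LNCaP cells (Homo sapiens) for cytotoxicity, read by MTT assay, with a stated time of 48 h, in the absence of a further agent (on this read-out lower numbers stand for stronger inhibition and higher numbers for weaker inhibition), compound 1 gives only a limit, > 100000 nM. Compound 3 likewise gives only a limit in this assay, > 100000 nM. Compound 2 stands with them: in this assay compound 2 gives only a limit, > 100000 nM. No ordering among the three is possible because of the limit of > 100000 nM in this assay, at which 3 of the 3 values shown sit.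

Compound 4, `COc1cc(NC(=O)c2csc(-c3c[nH]c4ccc(F)cc34)n2)cc(OC)c1OC`, is the next compound to be measured. Relative to compound 2 the change is fluoro in place of methoxy on an aromatic carbon of the fused benzene ring, while the trimethoxyanilide and the free indole hydrogen are kept. Among the measured compounds shown here, no measured pair differs in one place, so no step size is available to guide this change. Given that compound 2 and both companions sit at the assay limit, no step beyond the scatter is expected in either direction; the estimated step is a step that the limit leaves unreadable from compound 2 to compound 4. Compound 4 is expected to give about 150000 nM, within 40000 nM to 500000 nM, and most likely only a limit will be reported.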

Compound 4, half-maximal inhibitory concentration: > 100000 nM
Compound 4 was reported as a limit; the forecaster's own chance of this, stated with the estimate: 80%; the middle value does not contradict the limit.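

No step can be read from compound 2 to compound 4 in this assay, because both compounds are reported only as limits: the limit of > 100000 nM in this assay, at which 4 of the 4 values shown sit.

The compounds shown leave open whether fluoro in place of methoxy on an aromatic carbon alters cytotoxicity at all, and what change to the shared core would give a measurable value in this assay.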